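A few compounds are considered here, and "the series" means these few. Any claim that something is new, unique, unknown or untested is made for them only; others in the source may bear on it.

Measured compounds:
compound 1 `Cc1c(Nc2nc(N)c3c(C#N)c(N4CCC[C@H]4C)n(C)c3n2)cnn1C1COC1` with 190 nM
compound 2 `Cc1nn(C)cc1Nc1nc(N)c2c(C#N)c(N3CCC[C@H]3C)n(C)c2n1` with 120 nM

In an assay on HEK293 cells for inhibition of Leucine-rich repeat serine/threonine-protein kinase 2 variant G2019S (Homo sapiens), with a stated time of 48 h (on this read-out lower numbers stand for stronger inhibition and higher numbers for weaker inhibition), compound 1 gives 190 nM, and compound 2 gives 120 nM. Within the data shown here, the single measured step, a 1.6-fold lower number from compound 1 to compound 2 (0.20 log units; within the scatter), exchanges 5-methyl-1-(oxetan-3-yl)-1H-pyrazol-4-yl for 1,3-dimethyl-1H-pyrazol-4-yl on a nitrogen on an aromatic ring. Compound 2 holds the lowest number of the two, yet its distance from compound 1 lies within the scatter, so no order between them can be claimed.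

Compound 3 `C[C@@H]1CCCN1c1c(C#N)c2c(N)nc(Nc3cn(C)nc3C(F)(F)F)nc2n1C` differs from compound 2 by trifluoromethyl in place of methyl on an aromatic carbon. Among the measured compounds shown here, no measured step swaps methyl for trifluoromethyl at this place; the step from compound 1 to compound 2 alters a different part of the same group and was itself within the scatter. With nothing pointing either way, compound 3 is expected to stay close to compound 2, as no change at the digits printed from compound 2 to compound 3 (within the scatter). Compound 3 is therefore estimated at 120 nM in this assay, within a range of 45 nM to 320 nM.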

Compound 3, half-maximal inhibitory concentration: 460 nM
The estimate for compound 3 lay 3.8-fold (0.58 log units) below the measured number; measured number outside the range, above it.
By their numbers in this assay, from the lowest: compounds 2 and 1 (each within the scatter of the next); then compound 3.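

This place on the five-membered aromatic ring is not indifferent to what it carries. In this assay, among these compounds, trifluoromethyl in place of methyl gives a 3.8-fold higher number from compound 2 to compound 3 (0.58 log units; beyond the scatter), the first step here that lies beyond the scatter. Exchanging the whole group on the nitrogen gives a 2.4-fold higher number from compound 1 to compound 3 (0.38 log units; beyond the scatter), so 1-methyl-3-(trifluoromethyl)-1H-pyrazol-4-yl gives a higher number than either group set against it, and no measurement shown here accounts for this rise.

With only methyl and trifluoromethyl shown at this carbon, the compounds cannot say how a chlorine atom, an ethyl chain or a methoxy group would read there. Also open, going by these compounds, is whether the same exchange would give a similar step with oxetan-3-yl, rather than methyl, on the ring nitrogen.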